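From ethyl to vinyl on the chain of compound 3

The source may hold more compounds than are shown below. What is called first, only, known or untested is meant among the compounds shown, and "the series" means these compounds.

Measured in a functional assay on LoVo cells (Homo sapiens) for inhibition, read by colorimetric assay and MTT assay, with a stated time of 72 h; a lower number here means a stronger inhibitor, a higher number a weaker inhibitor:
Compound 1 `COc1ccc2c(c1)-c1cnc(n1C)OCCCCCCCCO2`: 34000 nM
Compound 2 `C=CCCCCCOc1ncc(-c2ccccc2OCCCCC=C)n1C`: 32000 nM
Compound 3 `CCCCCCOc1ncc(-c2ccccc2OC)n1C`: 27000 nM

These three compounds differ visibly in structure, yet their values lie within the scatter of one another. Compound 3, at 27000 nM, therefore cannot be separated from compound 2 or compound 1 in this assay. All three are weak inhibitors on these numbers, and none stands out from the others.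

The next compound to be tested is compound 4 `C=CCCCCOc1ncc(-c2ccccc2OC)n1C`. Its difference from compound 3 is small: vinyl in place of ethyl on a saturated chain carbon, four bonds along the chain from an oxygen on an aromatic ring. In words, vinyl takes the place of ethyl on a saturated chain carbon, four bonds along the chain from an oxygen on an aromatic ring. Cut one bond further out, the same difference reads pentyl to pent-4-en-1-yl.

No measured pair among these compounds shows this change on its own, so the expectation rests on the narrow spread of the three values. The expected result is a 1.1-fold higher number from compound 3 to compound 4 (0.03 log units; within the scatter), with no change in either direction beyond the scatter. For compound 4 the estimated value is 29000 nM, with an expected range from 15000 nM to 55000 nM.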

Compound 4, half-maximal inhibitory concentration: 4000 nM
Compound 4: middle estimate off by 7.3-fold (0.86 log units), on the high side; measured number outside the range, below it.
By their numbers in this assay, from the lowest: compound 4; then compounds 3, 2 and 1 (each within the scatter of the next).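

In this assay, placing vinyl where ethyl stood on a saturated chain carbon, four bonds along the chain from an oxygen on an aromatic ring, gives a 6.8-fold lower number from compound 3 to compound 4 (0.83 log units; beyond the scatter), a step beyond the scatter. This shows that the chain end is a place where a small change can separate two compounds, even though the heavy-atom count of the group stays the same and the only listed gain is a double bond outside aromatic rings; the earlier values, all within the scatter of one another, gave no sign of this. Compound 2 also carries a vinyl group on its chain but differs from compound 4 in more than one place, so that pair cannot be read, and nothing shown accounts for the step.

The compounds shown rest on this single pair, so it stays open whether the step depends on the vinyl group itself or would hold at another distance along the chain. An ethynyl group at the same place, a longer chain ending in vinyl, or an amine or a carboxylic acid at the chain end would each bear on that question.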